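The compounds below may be only part of what the source reports. "The series", "measured", "known", "first", "only" and "open" are said of these compounds alone.

Of the compounds shown here, two have been measured so far in a functional assay on HeLa cells (Homo sapiens) for inhibition, read by MTT assay, with a stated time of 48 h; a higher number here means a weaker inhibitor, a lower number a stronger inhibitor. Compound 1 `O=C(Nc1cnn(-c2ccccc2)c1)c1cccc(NS(=O)(=O)c2ccccc2)c1` gives 15300 nM in this assay. Compound 2 `Cc1ccc(-n2cc(NC(=O)c3cccc(NS(=O)(=O)c4ccccc4)c3)cn2)cc1` carries a methyl group where compound 1 has a hydrogen; in this assay compound 2 gives 3120 nM. That single change produced a 4.9-fold lower number from compound 1 to compound 2 (0.69 log units; beyond the scatter), so compound 2 stands as the lower of the two numbers, the stronger inhibitor of the two.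

Compound 3 `COc1ccc(-n2cc(NC(=O)c3cccc(NS(=O)(=O)c4ccccc4)c3)cn2)cc1` has not yet been measured. It differs from compound 2 in one place: methoxy in place of methyl on an aromatic carbon. Among the compounds with values here, no measured step covers a swap of methyl for methoxy; the only step in hand, a 4.9-fold lower number from compound 1 to compound 2 (0.69 log units; beyond the scatter), concerns putting methyl in place of hydrogen on the same aromatic carbon, and it cannot tell whether a methoxy group there behaves like methyl, like hydrogen, or otherwise. With nothing to push the expectation either way, the reasonable guess is a number close to that of compound 2, and the step is expected to be a 1.1-fold higher number from compound 2 to compound 3 (0.05 log units; within the scatter), within the scatter. Compound 3 is therefore estimated at 3500 nM in this assay, with a likely range from 1200 nM to 10000 nM.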

Compound 3, half-maximal inhibitory concentration: 42200 nM
For compound 3 the middle estimate is 12-fold (1.08 log units) below the measured one; the measured number lies above the stated range.
By their numbers in this assay, from the lowest: compound 2; then compound 1; then compound 3.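

In this assay, the change from 4-methylphenyl to 4-methoxyphenyl gives a 14-fold higher number from compound 2 to compound 3 (1.13 log units; beyond the scatter), a large step for a swap that adds only one oxygen and one hydrogen-bond acceptor, so this ring position clearly distinguishes between two groups of similar size by heavy-atom count. Methoxy also gives a 2.8-fold higher number from compound 1 to compound 3 (0.44 log units; beyond the scatter), which places it on the opposite side of hydrogen from methyl; among these three compounds, then, a group at this carbon can move the number in either direction, and filling the position does not by itself lower it. Nothing measured here bears on why methyl and methoxy differ so much.

The compounds shown leave open whether the lower number belongs to methyl alone or extends to other groups, such as an ethyl group, a chlorine atom or a trifluoromethyl group. They also leave open whether the penalty seen with methoxy is specific to that group or is shared by a hydroxyl group, a longer ethoxy chain or a dimethylamino group.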